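The compounds below may be only part of what the source reports. "The series", "measured", "known", "first", "only" and "open" are said of these compounds alone.

Series notes. Compound 1 `Cc1ccc(CNC(=O)c2cccc(C(C)Oc3cccnc3Nc3cnn(CC(C)(C)O)c3)c2)cc1` gives 20500 nM in a functional assay on HCC78 cells (Homo sapiens) for antiproliferative activity, read by MTT assay, with a stated time of 48 h; on this read-out lower numbers stand for stronger inhibition and higher numbers for weaker inhibition. Going by the values given here, compound 2 `Cc1ccc(CNC(=O)c2cccc(C(C)Oc3cccnc3Nn3cnnc3)c2)cc1` gives 9400 nM in this assay, the lowest of the two numbers so far; the only measured step, a 2.2-fold lower number from compound 1 to compound 2 (0.34 log units; beyond the scatter), separates the pair. Compound 3 `Cc1ccc(CNC(=O)c2cccc(C(C)Oc3cccnc3Nc3nncs3)c2)cc1` is not yet measured; it differs from compound 2 by 1,3,4-thiadiazol-2-yl in place of 4H-1,2,4-triazol-4-yl on a nitrogen on an aromatic ring. Among the compounds with values here, no measured step exchanges one five-membered aromatic ring with three hetero atoms for another on that nitrogen. The step from compound 1 to compound 2 replaced the 1-(2-hydroxy-2-methylpropyl)-1H-pyrazol-4-yl group and is only an indirect guide, showing that a change of ring on this nitrogen moved the number modestly. Within the data shown here, with no closer precedent, the expected step in this assay is a 1.1-fold lower number from compound 2 to compound 3 (0.04 log units; within the scatter), not clearly beyond the scatter in either direction. Compound 3 is therefore estimated at 8500 nM, within a range of 3000 nM to 25000 nM.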

Compound 3, half-maximal inhibitory concentration: 17600 nM
Compound 3: the middle estimate sits 2.1-fold (0.32 log units) below what was measured; the range from low to high includes it.
By their numbers in this assay, from the lowest: compounds 2, 3 and 1 (each within the scatter of the next, the first and the last beyond it).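

Series notes, continued. In this assay, going by these compounds alone, the 1,3,4-thiadiazol-2-yl in place of the 4H-1,2,4-triazol-4-yl gives a 1.9-fold higher number from compound 2 to compound 3 (0.27 log units; within the scatter) and is the first reading of one five-membered aromatic ring with three hetero atoms exchanged for another on this nitrogen. With a 1.2-fold lower number from compound 1 to compound 3 (0.07 log units; within the scatter) as well, the 1,3,4-thiadiazol-2-yl cannot be told apart from the 1-(2-hydroxy-2-methylpropyl)-1H-pyrazol-4-yl at this position, so only a 2.2-fold lower number from compound 1 to compound 2 (0.34 log units; beyond the scatter) remains as a step beyond the scatter. Nothing on hand bears on the origin of these numbers.

On these data alone, it remains open whether a group of another kind on this nitrogen, such as a plain methyl or a morpholine ring, would move the number further in this assay. Also open is whether the small differences among these three rings would persist with a carboxylic acid on the shared core.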